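A Methoxy Group Added to Compound 2

The compounds below may be only part of what the source reports. "The series", "measured", "known", "first", "only" and "open" are said of these compounds alone.

In an ADME assay on NIH3T3 cells (Mus musculus) for cytotoxicity, read by MTT assay, with a stated time of 48 h (on this read-out higher numbers stand for lower toxicity in this test and lower numbers for higher toxicity in this test), compound 1 `COc1ccc(C(=O)/C=C/c2ccccc2)cc1S(N)(=O)=O` gives 7700 nM, while compound 2 `COc1ccc(C(=O)/C=C/c2ccccc2)cc1S(=O)(=O)Nc1c(N)nc(SC)[nH]c1=O` gives 17000 nM, the highest of the two numbers. Compound 2 is therefore the less toxic of the pair in this test, though not by much. Among the compounds with values here, the only measured step, a 2.2-fold higher number from compound 1 to compound 2 (0.34 log units; beyond the scatter), is modest and comes with a larger group replacing a hydrogen atom on a sulfonamide nitrogen.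

Compound 3 `COc1ccc(/C=C/C(=O)c2ccc(OC)c(S(=O)(=O)Nc3c(N)nc(SC)[nH]c3=O)c2)cc1` departs from compound 2 by a single change: methoxy in place of hydrogen on an aromatic carbon. This places methoxy in place of hydrogen on an aromatic carbon, para to a large group. Within the data shown here, no measured pair shows this change, and the one available step lies at a different place in the molecule. That step gives only a rough idea of how far the numbers move in this small set, and it gives no direction for the new change. In this assay, the expected step is a 1.1-fold lower number from compound 2 to compound 3 (0.05 log units; within the scatter), so no shift beyond the scatter is expected. Compound 3 is estimated at 15000 nM, with an expected range of 7000 nM to 32000 nM.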

Compound 3, concentration lethal to 50% of the cells: 6500 nM
Compound 3: middle estimate off by 2.3-fold (0.36 log units), on the high side; measured number below the stated range.
By their numbers in this assay, from the lowest: compounds 3 and 1 (each within the scatter of the next); then compound 2.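

In this assay, the change from phenyl to 4-methoxyphenyl gives a 2.6-fold lower number from compound 2 to compound 3 (0.42 log units; beyond the scatter), so methoxy in place of hydrogen at this place, para to a large group, is not a neutral change: the modest step goes toward higher toxicity in this test. Within the data shown here, the earlier step concerned only the sulfonamide nitrogen, so this result is the first to show that the number also responds to a change in the 2-phenylethenyl part of the molecule. Nothing in the available evidence accounts for the shift.

A single pair cannot separate what is particular to methoxy from what any group on this aromatic carbon might do, and a hydroxyl, a methyl or a chlorine at the same place would be needed to tell these apart. As far as these compounds go, it also remains open whether methoxy at this place would move the number in the same direction and by a similar size on compound 1, which keeps the unsubstituted sulfonamide.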